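The source may report more compounds than this note shows. Statements on the series, on what has been measured and on what is new or still open speak of the compounds shown alone.

Of the compounds shown here, two sharing one core have been tested in a functional assay on NCI-H460 cells (Homo sapiens) for inhibition, read by MTT assay, with a stated time of 72 h; a lower number here means a stronger inhibitor, a higher number a weaker inhibitor. Compound 1 `COc1cc2c(Oc3ccc(NC(=O)c4nn(-c5ccccc5C(F)(F)F)c(=O)cc4C)cc3F)ccnc2cc1OCCCN1CCCC1` gives 210 nM in this assay. Compound 2 `COc1cc2c(Oc3ccc(NC(=O)c4nn(-c5cccc(F)c5)c(=O)cc4C)cc3F)ccnc2cc1OCCCN1CCCC1` gives 280 nM in this assay; its nearest neighbour among the measured compounds is compound 1, and the two numbers lie within the scatter of each other. Among the measured compounds shown here, the single measured step, a 1.3-fold higher number from compound 1 to compound 2 (0.12 log units; within the scatter), changes only the group on the aromatic nitrogen and stays within the scatter.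

Compound 3 `COc1cc2c(Oc3ccc(NC(=O)c4nn(-c5ccc(Cl)cc5)c(=O)cc4C)cc3F)ccnc2cc1OCCCN1CCCC1` has not yet been measured. It differs from compound 2 in one place: 4-chlorophenyl in place of 3-fluorophenyl on an aromatic nitrogen. This is again an exchange of the group on the same aromatic nitrogen, the same kind of change as the step from compound 1 to compound 2, which was within the scatter, so no step beyond the scatter is expected here either. Compound 3 is therefore expected to give about 250 nM in this assay, with a likely range from 110 nM to 600 nM. This estimate means a step of a 1.1-fold lower number from compound 2 to compound 3 (0.05 log units; within the scatter), expected to remain within the usual scatter.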

Compound 3, half-maximal inhibitory concentration: 360 nM
Compound 3: the middle estimate sits 1.4-fold (0.16 log units) below what was measured; low and high end bracket the measured number.
By their numbers in this assay, from the lowest: compounds 1, 2 and 3 (each within the scatter of the next).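

In this assay, putting 4-chlorophenyl in place of 3-fluorophenyl on the aromatic nitrogen gives a 1.3-fold higher number from compound 2 to compound 3 (0.11 log units; within the scatter) and putting it in place of 2-(trifluoromethyl)phenyl gives a 1.7-fold higher number from compound 1 to compound 3 (0.23 log units; within the scatter), so neither new step leaves the scatter. This position has now carried three different substituted phenyl groups, with trifluoromethyl, fluorine and chlorine each at a different place on the ring, and this assay does not separate any of the three compounds from one another. Nothing in the data shown explains why these groups give such similar numbers.

From the compounds shown here alone, it remains open whether this tolerance reaches beyond phenyl rings bearing halogen-containing groups: a phenyl ring carrying an amine or a carboxylic acid, or a butyl chain on the same nitrogen, might move the number beyond the scatter or might leave it unchanged. Going by these compounds, the three compounds also change the substituent and its place on the ring together, so the effect of moving one substituent around the ring, such as chlorine from the 4-position to the 2-position, remains unknown.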